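This account rests on a few compounds, and the source may have more. Where it says the series, first, only, none or still open, it means among the compounds named here.

Working notes on the series. Compound 1 `Cn1nc2c(=O)n(CC3(O)CCN(Cc4ccc(-c5ccc[nH]5)cc4Cl)CC3)cnc2c1-c1ccc(CN)cc1` gives 193 nM in an assay on isolated protein for inhibition of ubiquitin carboxyl-terminal hydrolase 7 (Homo sapiens), with stated times of 30 min and 2 h; a higher number here means a weaker inhibitor, a lower number a stronger inhibitor. Among the measured compounds shown here, compound 2 `Cn1nc2c(=O)n(CC3(O)CCN(Cc4ccc(-c5ccsc5Cl)cc4Cl)CC3)cnc2c1-c1ccc(CN)cc1` gives 453 nM in this assay, and the step of a 2.3-fold higher number from compound 1 to compound 2 (0.37 log units; beyond the scatter) is the only change recorded so far at this position. Compound 2 stands at the higher of the two numbers measured, with compound 1 the nearest neighbour. Compound 3 `Cn1nc2c(=O)n(CC3(O)CCN(Cc4ccc(-c5cncs5)cc4Cl)CC3)cnc2c1-c1ccc(CN)cc1` is not yet measured; it differs from compound 2 by 1,3-thiazol-5-yl in place of 2-chlorothiophen-3-yl on an aromatic carbon. For the measured compounds named here, the one step that bears on this exchange is a 2.3-fold higher number from compound 1 to compound 2 (0.37 log units; beyond the scatter), a swap of one five-membered ring for another at the same carbon, and it was modest. A step of similar size is therefore expected here, most likely back toward the number of compound 1, so compound 3 is estimated at a 1.5-fold lower number from compound 2 to compound 3 (0.18 log units; within the scatter). The estimate for compound 3 in this assay is 300 nM, with a range from 120 nM to 750 nM.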

Compound 3, half-maximal inhibitory concentration: 117 nM
Estimate against measurement, compound 3: 2.6-fold (0.41 log units) above; the measured number lies below the stated range.
By their numbers in this assay, from the lowest: compounds 3 and 1 (each within the scatter of the next); then compound 2.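

In this assay, a 3.9-fold lower number from compound 2 to compound 3 (0.59 log units; beyond the scatter) shows that 2-chlorothiophen-3-yl stands apart at this position: compound 2 carries the highest number, and its steps to the other two compounds lie beyond the scatter. A ring sulfur alone does not go with the higher number, since 1,3-thiazol-5-yl also carries one, while a 1.6-fold lower number from compound 1 to compound 3 (0.22 log units; within the scatter) lies within the scatter, so 1,3-thiazol-5-yl and 1H-pyrrol-2-yl cannot be told apart here. No supporting data bear on why this exchange shifts the number.

The ring and its chlorine change together, so the compounds shown leave open which of them accounts for the difference; a thiophen-3-yl without the chlorine would separate them. Also open, on these data alone, is how a six-membered pyridinyl ring, or an aminomethyl group on the 1,3-thiazol-5-yl ring, would read at this carbon.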